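The source may hold more compounds than are shown below. What is called first, only, known or untested is meant among the compounds shown, and "the series" means these compounds.

Series notes. Compound 2 `CC(=O)c1cccc(NC(=O)C2CCCN(C(=O)c3cc(C(F)(F)F)cc(C(F)(F)F)c3)C2)c1` gives 0% in an ADME assay on PC-3 cells (Homo sapiens) for cytotoxicity, read by WST assay, tested at 100 uM; on this read-out lower numbers stand for less inhibition and higher numbers for more inhibition at the one concentration tested (going by the name of the read-out). Compound 1 `O=C(Nc1cccc(OCCc2ccccn2)c1)C1CCCN(C(=O)c2cc(C(F)(F)F)cc(C(F)(F)F)c2)C1` gives 5% in this assay, and compound 3 `COC(=O)c1cc(-c2cccc(NC(=O)C3CCCN(C(=O)c4cc(C(F)(F)F)cc(C(F)(F)F)c4)C3)c2)co1` gives 0%. Compound 2 thus stands level with compound 3 at the digits reported, and compound 1 is the furthest of the three from it; the step of a number 5 percentage points lower from compound 1 to compound 2 (within the scatter) lies within the scatter, as do a number 5 percentage points lower from compound 1 to compound 3 (within the scatter) and no change at the digits printed from compound 2 to compound 3 (within the scatter). Compound 4 `O=C(Nc1ccc(Cl)cn1)C1CCCN(C(=O)c2cc(C(F)(F)F)cc(C(F)(F)F)c2)C1` is not yet measured in this assay. It differs from compound 2 in one place: 5-chloropyridin-2-yl in place of 3-acetylphenyl on an amide-type nitrogen. Going by the values given here, none of the measured steps touches the amide-type nitrogen; all three concern a group on an aromatic carbon, and none of them moved the number beyond the scatter. Nothing among the three measured compounds points to a different outcome here, so the expected step of a number 3 percentage points higher from compound 2 to compound 4 (within the scatter) is none beyond the scatter. Compound 4 is therefore estimated at 3%, with a range from -5% to 15%.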

Compound 4, a percentage reported as inhibition, at one concentration (the size of the read-out at that concentration, not a potency): 0%
Compound 4: middle estimate off by 3 percentage points, on the high side; the range from low to high includes it.
By their numbers in this assay, from the lowest: compounds 2, 3, 4 and 1 (each within the scatter of the next).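

In this assay, the exchange of 3-acetylphenyl for 5-chloropyridin-2-yl on the amide-type nitrogen gives no change at the digits printed from compound 2 to compound 4 (within the scatter). Going by these compounds alone, the earlier steps all concerned a group on an aromatic carbon, so this is the first reading at this position: here, an aromatic ring of carbon only and a chlorine-bearing aromatic ring with 1 hetero atom cannot be told apart by this read-out. No available measurement bears on why the number holds.

Open, going by these compounds, is whether a non-aromatic group on this nitrogen, such as a longer alkyl chain or a chain ending in an amine or a carboxylic acid, would move the number beyond the scatter. With all four compounds within the scatter of one another, the series does not yet rank any group.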